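This account rests on a few compounds, and the source may have more. Where it says the series, first, only, none or still open, it means among the compounds named here.

Measured so far in a functional assay for inhibition of Polyunsaturated fatty acid 5-lipoxygenase (Homo sapiens); a lower number here means a stronger inhibitor, a higher number a weaker inhibitor:
compound 1 `C=CCC(O/N=C(\C)C(=O)O)c1ccc(OCc2ccc3ccccc3n2)cc1` gives 142 nM;
compound 2 `CCCCC(CCCC)C(O/N=C(\C)C(=O)O)c1ccc(OCc2ccc3ccccc3n2)cc1` gives 14 nM;
compound 3 `C/C(=N\OC(c1ccc(OCc2ccc3ccccc3n2)cc1)C1CCCCCC1)C(=O)O` gives 13 nM.

Compound 3 and compound 2 sit together at the low end of these numbers; the step of a 1.1-fold lower number from compound 2 to compound 3 (0.03 log units; within the scatter) lies within the scatter, and only compound 1 stands clearly apart. The next compound, compound 4 `C/C(=N\OC(Cc1ccccc1)c1ccc(OCc2ccc3ccccc3n2)cc1)C(=O)O`, changes one group: benzyl in place of cycloheptyl on a saturated chain carbon bound to an aromatic carbon and an oxygen. Going by the values given here, two measured steps bear on this spot, an 11-fold lower number from compound 1 to compound 3 (1.04 log units; beyond the scatter) and a 10-fold lower number from compound 1 to compound 2 (1.01 log units; beyond the scatter): a larger group here gave a much lower number than allyl. Benzyl matches cycloheptyl in count but brings an aromatic six-membered ring in place of a non-aromatic seven-membered one, a change no measured compound tests. Part of the gain is expected to be kept, so a 3.1-fold higher number from compound 3 to compound 4 (0.49 log units; beyond the scatter) is estimated. Compound 4 is therefore expected to give about 40 nM, within 12 nM to 130 nM.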

Compound 4, half-maximal inhibitory concentration: 30 nM
The estimate for compound 4 lay 1.3-fold (0.12 log units) above the measured number; the range from low to high includes it.
By their numbers in this assay, from the lowest: compounds 3 and 2 (each within the scatter of the next); then compound 4; then compound 1.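

In this assay, going by these compounds alone, benzyl is the first large group here to separate from the others, with a 2.3-fold higher number from compound 3 to compound 4 (0.36 log units; beyond the scatter) and a 2.1-fold higher number from compound 2 to compound 4 (0.33 log units; beyond the scatter), both modest but beyond the scatter. Benzyl and cycloheptyl have the same count of heavy atoms, so that count alone does not set the number at this position. Benzyl still keeps much of the gain over allyl, with a 4.7-fold lower number from compound 1 to compound 4 (0.68 log units; beyond the scatter).

Nothing available explains the difference between benzyl and cycloheptyl. As far as these compounds go, how cyclohexyl or a longer chain ending in phenyl would behave here remains open.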